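Trading a trifluoromethyl for a pyrazole on the amide carbonyl

The source may hold more compounds than are shown below. What is called first, only, known or untested is meant among the compounds shown, and "the series" means these compounds.

Measured values in a physicochemical assay for lipophilicity, read by HPLC, measured as chromatographic lipophilicity, at pH 7.4; on this read-out higher numbers stand for higher lipophilicity and lower numbers for lower lipophilicity:

Compound 1 `O=C(C1CCN(C(=O)C(F)(F)F)CC1)N1N=CCC1c1ccccc1` gives 4.9.
Compound 2 `N#Cc1cc(N2CCC(C(=O)N3N=CC[C@H]3c3cc(F)cc(F)c3)CC2)ncn1` gives 5.
Compound 3 `O=C(C1CCCC1)N1N=CCC1c1ccccc1` gives 5.4.

Compound 1 and compound 2 sit within the scatter of each other in this assay, so the two values cannot be told apart. Compound 3 lies beyond the scatter above compound 1; no single-point comparison links these two structures, so only the two values themselves can be read.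

Compound 4 `O=C(c1cc[nH]n1)N1CCC(C(=O)N2N=CCC2c2ccccc2)CC1` has not been measured in this assay. It differs from compound 1 in one place:

1H-pyrazol-3-yl in place of trifluoromethyl on a carbonyl carbon

Among the measured compounds shown here, with no measured pair of this kind to draw on, the expectation rests on the counted difference alone: a group with one hydrogen-bond donor and one hydrogen-bond acceptor in place of one with neither, on the carbonyl carbon. A fall beyond the scatter in this assay is expected, and the estimated step of a number 1.30 log units lower from compound 1 to compound 4 (beyond the scatter) reflects that, starting from the value of compound 1 of 4.9. Compound 4 is therefore estimated at 3.6, with a range from 2.9 to 4.3.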

Compound 4, distribution coefficient: 2.4
The estimate for compound 4 lay 1.20 log units above the measured number; the measured number lies below the stated range.
By their numbers in this assay, from the lowest: compound 4; then compounds 1 and 2 (each within the scatter of the next); then compound 3.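

In this assay, among the compounds shown here, 1H-pyrazol-3-yl in place of trifluoromethyl on this carbonyl carbon gives a number 2.50 log units lower from compound 1 to compound 4 (beyond the scatter), the only step here between measured compounds that differ in one place, and it shows that the read-out responds strongly to the group at this position. The entering group brings a ring, a hydrogen-bond donor and a hydrogen-bond acceptor that trifluoromethyl lacks, so these differences all arrive in one change. Nothing available explains the size of this step.

The compounds shown cannot separate the contribution of the ring from that of the hydrogen-bond donor and acceptor. From the compounds shown here alone, a furan ring or a phenyl ring on the same carbonyl carbon would bear on that question, and how either would read remains open.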